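A few compounds are considered here, and "the series" means these few. Any claim that something is new, unique, unknown or untested is made for them only; others in the source may bear on it.

In a functional assay on SW1573 cells (Homo sapiens) for antiproliferative activity, read by sulforhodamine B assay, with a stated time of 48 h (a lower number here means a stronger inhibitor of growth, a higher number a weaker inhibitor of growth), compound 1 `CCCCCCCCC[C@@H](O)[C@@H](N)[C@@H](C)CC` gives (13000 nM) and compound 2 `CCCCCCCCC[C@@H](O)[C@@H](N)C(C)C` gives (17000 nM). Among the measured compounds shown here, these two values lie within the scatter of each other, so compound 2 stands level with the only other compound measured. Compound 3 `CCCCCCCCC[C@@H](O)[C@@H](N)[C@@H](C)O` carries 1-hydroxyethyl in place of the isopropyl of compound 2, on a saturated chain carbon bound to an amine nitrogen and a saturated chain carbon (1-hydroxyethyl in place of isopropyl on a saturated chain carbon bound to an amine nitrogen and a saturated chain carbon). For the measured compounds named here, the sole measured step is small (a 1.3-fold higher number from compound 1 to compound 2 (0.12 log units; within the scatter)) and is only a weak guide, as it swaps methyl for hydrogen and no measured compound holds 1-hydroxyethyl. No shift beyond the scatter is therefore expected in this assay, though with wide uncertainty. The expected step is small (a 1.1-fold lower number from compound 2 to compound 3 (0.03 log units; within the scatter)). The estimate for compound 3 is 16000 nM (expected range 6000 nM to 45000 nM).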

Compound 3, concentration for 50% growth inhibition: 17000 nM
The estimate for compound 3 lay 1.1-fold (0.03 log units) below the measured number, within the range that was stated.
By their numbers in this assay, from the lowest: compounds 1, 2 and 3 (each within the scatter of the next).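

In this assay, putting 1-hydroxyethyl in place of isopropyl on a saturated chain carbon bound to an amine nitrogen and a saturated chain carbon gives a clear result (no change at the digits printed from compound 2 to compound 3 (within the scatter)). Of the three compounds, only compound 3 holds an oxygen in this group, and with it a hydrogen-bond donor, a hydrogen-bond acceptor and a defined stereocentre, yet its number stands level with the others, as the step with hydroxy in place of ethyl on a saturated chain carbon bound to two saturated chain carbons also shows (a 1.3-fold higher number from compound 1 to compound 3 (0.12 log units; within the scatter)). No available evidence explains this result.

On these data alone, it remains open whether an amine, a carboxylic acid or a longer chain in this place would give a number beyond the scatter. The opposite arrangement at the stereocentre of the 1-hydroxyethyl group is also left open.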